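Sulfamate series: pyridylmethyl to fluorobenzyl on the aniline nitrogen

This account rests on a few compounds, and the source may have more. Where it says the series, first, only, none or still open, it means among the compounds named here.

Compound 3 `CCN(Cc1ccncc1)c1ccc(C(=O)N2CCc3ccc(OS(N)(=O)=O)cc3C2)cc1` gives 86.6% in an assay on HEK293 cells for inhibition of Steryl-sulfatase (Homo sapiens), tested at 1 uM (on this read-out lower numbers stand for a weaker effect and higher numbers for a stronger effect at the one concentration tested), the highest of the three numbers as read, although compound 2 `CCN(Cc1cccnc1)c1ccc(C(=O)N2CCc3ccc(OS(N)(=O)=O)cc3C2)cc1` gives 85.2% and the step of a number 1.4 percentage points higher from compound 2 to compound 3 (within the scatter) lies within the scatter. Compound 1 `CN(C)CCN(CCN(C)C)c1ccc(C(=O)N2CCc3ccc(OS(N)(=O)=O)cc3C2)cc1` gives 15.9%, and both a number 69.3 percentage points higher from compound 1 to compound 2 (beyond the scatter) and a number 70.7 percentage points higher from compound 1 to compound 3 (beyond the scatter) are large.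

Compound 4 `CCN(Cc1ccc(F)cc1)c1ccc(C(=O)N2CCc3ccc(OS(N)(=O)=O)cc3C2)cc1` is not yet measured; its difference from compound 3 is 4-fluorophenyl in place of pyridin-4-yl on a saturated chain carbon bound to a nitrogen on an aromatic ring. Of the measured steps only a number 1.4 percentage points higher from compound 2 to compound 3 (within the scatter) concerns the same place, and it stayed within the scatter. The two large steps from compound 1 concern the amino group on the aromatic carbon, not the ring on the saturated chain carbon, so they do not bear on this change. Within the data shown here, no measured pair exchanges pyridin-4-yl for 4-fluorophenyl, so the direction is open. The expected step of a number 6.6 percentage points lower from compound 3 to compound 4 (within the scatter) is therefore one not beyond the scatter, with a wide range to cover the untested exchange. Compound 4 is estimated in this assay at 80%, from 55% to 95%.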

Compound 4, a percentage reported as inhibition, at one concentration (the size of the read-out at that concentration, not a potency) in the Steryl-sulfatase assay: 91.2%
Estimate against measurement, compound 4: 11.2 percentage points below; the measured number falls inside the stated range.
By their numbers in the Steryl-sulfatase assay, from the lowest: compound 1; then compounds 2, 3 and 4 (each within the scatter of the next).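

In the Steryl-sulfatase assay compound 4 gives 91.2% and the exchange for 4-fluorophenyl gives a number 4.6 percentage points higher from compound 3 to compound 4 (within the scatter) and a number 6 percentage points higher from compound 2 to compound 4 (within the scatter) so this saturated chain carbon carries a carbon-only ring with fluorine as well as it carries either pyridine, and the ring nitrogen is not required among these compounds. In the Steryl-sulfatase assay and with a number 75.3 percentage points higher from compound 1 to compound 4 (beyond the scatter) the ethyl(4-fluorobenzyl)amino group keeps the large gap to bis(2-(dimethylamino)ethyl)amino. In a physicochemical assay for lipophilicity (on this read-out higher numbers stand for higher lipophilicity and lower numbers for lower lipophilicity), compound 3 gives 1.93 and compound 4 gives 1.93 and the pyridin-4-yl exchange gives no change at the digits printed from compound 3 to compound 4 (within the scatter) so neither read-out separates these two rings. No measured evidence accounts for these results.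

From the compounds shown here alone, whether this position accepts a ring bearing a carboxylic acid or a primary amine, or a plain longer alkyl chain in place of the ring, stays open. Compound 2, compound 3 and compound 4 also remain unranked at the one concentration tested.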